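The source may hold more compounds than are shown below. What is called first, only, known or untested is meant among the compounds shown, and "the series" means these compounds.

Of the compounds shown here, three built on one shared core have been measured in a physicochemical assay for acid dissociation. Compound 1 `c1ccc(Oc2ccc3c(NCCCNCc4ccco4)ccnc3c2)cc1` gives 9.28. Compound 2 `COc1cccc(CNCCCNc2ccnc3cc(-c4ccccc4)ccc23)c1O` gives 9.47, and compound 3 `COc1cccc(CNCCCNc2ccnc3cc(Oc4ccccc4)ccc23)c1O` gives 9.28. Compound 1 stands level with compound 3 at the digits shown, and the two together are the lowest of the three readings; compound 2 lies within the scatter of both, so none of the three can be told apart with confidence.

Compound 4 `c1ccc(Cc2ccc3c(NCCCNCc4ccco4)ccnc3c2)cc1` is the next compound, differing from compound 1 in one place: benzyl in place of phenoxy on an aromatic carbon. The step that bears most directly on this change is a number 0.19 log units lower from compound 2 to compound 3 (within the scatter), which swapped a group on the same aromatic carbon and stayed within the scatter. The step of no change at the digits printed from compound 1 to compound 3 (within the scatter) shows that a change on the chain also left the number unchanged. A group swap on this aromatic carbon is therefore expected to give no step beyond the scatter, so the expected step is a number 0.07 log units higher from compound 1 to compound 4 (within the scatter). Compound 4 is estimated at 9.35, expected to fall between 9.05 and 9.65.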

Compound 4, acid dissociation constant: 9.47
Compound 4: the middle estimate sits 0.12 log units below what was measured, and the stated range covers the measured number.
By their numbers in this assay, from the lowest: compounds 1, 3, 2 and 4 (each within the scatter of the next).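

Swapping phenoxy for benzyl keeps the same count of heavy atoms and the single aromatic ring of carbon only, but takes away the one hydrogen-bond acceptor, and in this assay this gives a number 0.19 log units higher from compound 1 to compound 4 (within the scatter). This aromatic carbon has now carried three groups, and this second swap there, made with furan-2-yl rather than 2-hydroxy-3-methoxyphenyl on the chain, also stays within the scatter. No measurement at hand offers an explanation for this result.

Every group shown on this carbon contains an aromatic ring of carbon only, so the compounds leave open whether an amine or a carboxylic acid there would move the number beyond the scatter. Within the data shown here, also open is whether a longer chain in place of the one in compound 1 would do so.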